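Swapping Methyl for Phenyl on an Ester Carbonyl

The compounds below may be only part of what the source reports. "The series", "measured", "known", "first", "only" and "open" are said of these compounds alone.

Measured so far in a functional assay on KB cells (Homo sapiens) for cytotoxicity; on this read-out higher numbers stand for weaker inhibition and lower numbers for stronger inhibition:
Compound 1, `O=C(OC1=CC(=O)c2ccccc2C1=O)c1ccccc1`: compound 1 gives 36900 nM.
Compound 2, `CC(=O)OC1=CC(=O)c2ccccc2C1=O`: compound 2 gives 38800 nM.
Compound 3, `CC(=O)Oc1ccc2c(c1)C(=O)C=CC2=O`: compound 3 gives 22100 nM.

Compound 2 and compound 3 share the same atoms joined differently; the difference between the two cores is not broken down here. Compound 1 arises from compound 2 by phenyl in place of methyl on a carbonyl carbon, and the step of a 1.1-fold lower number from compound 2 to compound 1 (0.02 log units; within the scatter). The unmeasured compound 4, `O=C(Oc1ccc2c(c1)C(=O)C=CC2=O)c1ccccc1`, arises from compound 3 by the same change, (phenyl in place of methyl on a carbonyl carbon), on the same kind of place. For the measured compounds named here, since the one earlier instance of this change left the number essentially unmoved, compound 4 is expected to sit close to compound 3 in this assay, with an expected step of a 1.1-fold lower number from compound 3 to compound 4 (0.04 log units; within the scatter). The estimate for compound 4 is 20000 nM, expected to fall between 8000 nM and 50000 nM.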

Compound 4, half-maximal inhibitory concentration: 12100 nM
Compound 4: middle estimate off by 1.7-fold (0.22 log units), on the high side; measured number inside the range.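

In this assay, putting phenyl in place of methyl on a carbonyl carbon gives a 1.8-fold lower number from compound 3 to compound 4 (0.26 log units; within the scatter), while the earlier instance gave a 1.1-fold lower number from compound 2 to compound 1 (0.02 log units; within the scatter). The two steps cannot be told apart: the same change on two cores in this assay, a 1.1-fold lower number (0.02 log units; within the scatter) from compound 2 to compound 1 and a 1.8-fold lower number (0.26 log units; within the scatter) from compound 3 to compound 4, 1.7-fold (0.24 log units) apart, within the scatter of two such steps. For the compounds shown here, this fits the change behaving alike on both cores, but it rests on only two cores, and since neither step stands clear of the scatter, it does not show that the change moves the number on either one.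

The compounds shown carry only methyl or phenyl on this carbonyl carbon. Going by these compounds, it stays open what a longer chain such as butyl, or a phenyl ring bearing an amine or a carboxylic acid, would do on either core.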